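The source may report more compounds than this note shows. Statements on the series, on what has been measured and on what is new or still open speak of the compounds shown alone.

Measured so far:
compound 1 `Cc1cc(-c2ccsc2)cn2c(CSCCc3ccccc3)cnc12` — >= 4 ug/mL
compound 2 `Cc1cc(-c2cccs2)c2ncc(CSCCc3ccccc3)n2c1` — 100 ug/mL

In an ADME assay on HEL cells (Homo sapiens) for cytotoxicity, with a stated time of 3 days (a higher number here means that more compound is tolerated, a lower number that less compound is tolerated), compound 1 gives >= 4 ug/mL, and this is a limit of the assay, not a number. That is all that is known of compound 1 here: its true minimum cytotoxic concentration could sit anywhere from that limit upward, as the limit of >= 4 ug/mL in this assay, at which 1 of the 2 values shown sits, shows. In this assay compound 2 gives 100 ug/mL, a number rather than a limit.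

The next compound, compound 3 `Cc1cc(Br)cn2c(CSCCc3ccccc3)cnc12`, differs from compound 1 in one place: bromo in place of thiophen-3-yl on an aromatic carbon. The change is to a smaller group, bromo, on an aromatic carbon of the six-membered aromatic ring with one nitrogen in the shared core. Among the measured compounds shown here, no step between two measured compounds bears on this change, so nothing gives a direction; with a smaller, simpler group entering, no step beyond the usual scatter of this assay is expected in either direction, and the only anchor is the limit of compound 1 together with the value of compound 2.

The expected minimum cytotoxic concentration of compound 3 in this assay is 40 ug/mL, within 8 ug/mL to 100 ug/mL, which is an estimated step that the limit leaves unreadable from compound 1 to compound 3.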

Compound 3, minimum cytotoxic concentration: >= 2 ug/mL
Compound 3 gave a limit, no number (the forecaster's own chance of this, stated with the estimate: 50%); the middle value does not contradict the limit.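

Among the compounds shown here, compound 1 and compound 3 both give limits and not numbers in this assay and no step between them can be read. The compounds shown leave open whether bromo in place of thiophen-3-yl on an aromatic carbon shifts the minimum cytotoxic concentration at all, and if it does, in which direction and how far.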